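A few compounds are considered here, and "the series" means these few. Any claim that something is new, unique, unknown or untested is made for them only; others in the source may bear on it.

Compound 1 `N=C(N)NCCC[C@H](NC(=O)CN(c1nc(Cl)nc2[nH]cnc12)C1CC1)C(=O)O` is measured in a functional assay on the whole organism (Tail, strain ICR) with Mus musculus as the target, in the tail flick test, with a stated time of 90 min, at a dose of 25 umol/kg by the oral route (a higher number here means a stronger effect of the compound at the dose given, a lower number a weaker effect), where compound 1 gives 27.6%. Two companions share its core. Compound 2 `O=C(CN(c1ncnc2c1ncn2C1CCCCO1)C1CC1)NCC(=O)OCc1ccccc1` gives 25.9% in this assay; compound 3 `N=C(N)NCCC[C@H](NC(=O)CN(c1nc(Cl)nc2[nH]cnc12)C1CC1)C(=O)OCc1ccccc1` gives 30.4%. All three numbers lie within the scatter of one another, so compound 1 sits in the same band as compound 2 and compound 3, with no separation that the measurements support. For the measured compounds named here, the one step between compounds differing in a single place is that from compound 1 to compound 3, a number 2.8 percentage points higher from compound 1 to compound 3 (within the scatter), benzyl in place of hydrogen on an oxygen next to a carbonyl group.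

Compound 4 `NC(=O)CC[C@H](NC(=O)CN(c1nc(Cl)nc2[nH]cnc12)C1CC1)C(=O)O` differs from compound 1 by a group of 3 heavy atoms (1 carbon, 1 nitrogen, 1 oxygen; no ring) in place of a group of 5 heavy atoms (2 carbon, 3 nitrogen; no ring), on a saturated chain carbon, three bonds along the chain from an amide-type nitrogen and a carbonyl carbon. Going by the values given here, no measured step touches this part of the chain; the only step, from compound 1 to compound 3, concerned the oxygen at the carbonyl and stayed within the scatter. Nothing here therefore points to a step beyond the scatter in this assay in either direction. For compound 4 the expected step is a number 2.6 percentage points lower from compound 1 to compound 4 (within the scatter). Compound 4 is estimated at 25%, with a range from 10% to 40%.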

Compound 4, a percentage reported as activity, at one dose (the size of the read-out at that dose, not a potency): 41.1%
Compound 4: the middle estimate sits 16.1 percentage points below what was measured; the whole stated range lies below it.
By their numbers in this assay, from the lowest: compounds 2, 1 and 3 (each within the scatter of the next); then compound 4.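

In this assay the saturated chain carbon, three bonds along the chain from an amide-type nitrogen and a carbonyl carbon, is the one place in the series where a single change gives a step beyond the scatter: carbamoyl in place of the group of 5 heavy atoms gives a number 13.5 percentage points higher from compound 1 to compound 4 (beyond the scatter). The benzyl step at the other end of the molecule, a number 2.8 percentage points higher from compound 1 to compound 3 (within the scatter), showed no such separation. No measurement at hand accounts for the step.

As far as these compounds go, whether the step follows from carbamoyl itself or from the loss of the larger group stays open, and an amine or a carboxylic acid at this carbon, or carbamoyl on a longer chain, would help separate the two. Also open, from the compounds shown here alone, is whether benzyl on the oxygen of compound 4 leaves its read-out in place.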